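Branched Chain to Oxane Ring: Cytotoxicity Outlook

The source may hold more compounds than are shown below. What is called first, only, known or untested is meant among the compounds shown, and "the series" means these compounds.

Compound 2 (`CCCC(CCC)Nc1cc(Oc2c(OC)cc3cc(C#N)ccc3c2OC)nc(Nc2ccc(C#N)cc2)n1`) carries a 1-propylbutyl group on a nitrogen on an aromatic ring. In an ADME assay on MT4 cells (Homo sapiens) for cytotoxicity, read by MTT assay, with a stated time of 5 days (on this read-out lower numbers stand for higher toxicity in this test and higher numbers for lower toxicity in this test), compound 2 gives > 125000 nM, which is a limit of the assay rather than a number. Its closest measured neighbour is compound 1 (`COc1cc2cc(C#N)ccc2c(OC)c1Oc1cc(NCC(C)(C)C)nc(Nc2ccc(C#N)cc2)n1`), which differs only by a neopentyl group in that place. In this assay compound 1 gives > 125000 nM, also a limit. The step that the two limits leave unreadable from compound 1 to compound 2 cannot be read, since both values sit at the limit of > 125000 nM in this assay, at which 2 of the 2 values shown sit.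

Compound 3 (`COc1cc2cc(C#N)ccc2c(OC)c1Oc1cc(NCC2CCOCC2)nc(Nc2ccc(C#N)cc2)n1`) has not yet been measured. It changes compound 2 as follows: (oxan-4-yl)methyl in place of 1-propylbutyl on a nitrogen on an aromatic ring. Among the measured compounds shown here, no measured step speaks to this change directly, and the only step between measured compounds, a step that the two limits leave unreadable from compound 1 to compound 2, is unreadable. With both measured compounds at the same limit there is no ground to expect a readable shift in this assay, and the most likely outcome for compound 3 is again a limit. The step that the limit leaves unreadable from compound 2 to compound 3 is expected to be small. Compound 3 is estimated to give 150000 nM, with a range from 60000 nM to 400000 nM.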

Compound 3, half-maximal cytotoxic concentration: > 125000 nM
Compound 3: only a limit was reported (the forecaster's own chance of this, stated with the estimate: 80%); the middle value does not contradict the limit.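

In this assay compound 3 gives > 125000 nM, which is a limit of the assay and not a number. The steps from compound 1 to compound 3 and from compound 2 to compound 3 cannot be read, because all three compounds share one limit: the limit of > 125000 nM in this assay, at which 3 of the 3 values shown sit.

The compounds shown leave open whether the neopentyl, 1-propylbutyl and (oxan-4-yl)methyl groups differ at all in cytotoxicity.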